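Adding a Third Methoxy Group: Expectation for Compound 4

The source may report more compounds than this note shows. Statements on the series, on what has been measured and on what is new or still open speak of the compounds shown alone.

Three compounds have been measured in a functional assay on MCF7 cells (Homo sapiens) for cytotoxicity, read by sulforhodamine B assay, with a stated time of 48 h; on this read-out higher numbers stand for weaker inhibition of growth and lower numbers for stronger inhibition of growth:
compound 1, `COc1ccc(/C(Cl)=C/C=C(\C#N)C(=O)c2c[nH]c3ccccc23)cc1`, 47300 nM
compound 2, `COc1ccc(/C(Cl)=C/C=C(\C#N)C(=O)c2c[nH]c3ccccc23)cc1OC`, 44200 nM
compound 3, `COc1ccc(/C(Cl)=C/C=C(\C#N)C(=O)c2c(C)[nH]c3ccccc23)cc1OC`, 29600 nM

Compound 2 differs from compound 1 by methoxy in place of hydrogen on an aromatic carbon, and this step gave a 1.1-fold lower number from compound 1 to compound 2 (0.03 log units; within the scatter). Compound 3 carries methyl in place of hydrogen on an aromatic carbon relative to compound 2, with a 1.5-fold lower number from compound 2 to compound 3 (0.17 log units; within the scatter). Compound 3 and compound 1 differ in more than one place; the difference between these two cores is not broken down here.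

Compound 4, `COc1cc(/C(Cl)=C/C=C(\C#N)C(=O)c2c(C)[nH]c3ccccc23)cc(OC)c1OC`, is not yet measured. It differs from compound 3 by methoxy in place of hydrogen on an aromatic carbon. This is the same kind of change as that from compound 1 to compound 2, though in compound 4 the entering methoxy is also meta to a methoxy group. A step of a 1.1-fold lower number from compound 3 to compound 4 (0.06 log units; within the scatter) is expected in this assay because a 1.1-fold lower number from compound 1 to compound 2 (0.03 log units; within the scatter) stayed within the scatter. Compound 4 is therefore estimated at 26000 nM, with a range expected from 12000 nM to 60000 nM.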

Compound 4, concentration for 50% growth inhibition: < 100 nM
Compound 4: no number, only a limit (the forecaster's own chance of this, stated with the estimate: 5%); middle value at least 260-fold (2.41 log units) away from the limit.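

In this assay, methoxy in place of hydrogen on an aromatic carbon gave an at least 290-fold lower number from compound 3 to compound 4 (2.47 log units; beyond the scatter), so the change did not carry over from one core to the other with the same size: the same change on two cores in this assay, a 1.1-fold lower number (0.03 log units; within the scatter) from compound 1 to compound 2 and an at least 290-fold lower number (2.47 log units; beyond the scatter) from compound 3 to compound 4, at least 270-fold (2.44 log units) apart, beyond the scatter of two such steps. The result for compound 4 is a limit of the assay, not a number: the limit of < 100 nM in this assay, at which 1 of the 4 values shown sits. These two pairs show that the step is not transferable across these cores, but they do not show whether the methyl of compound 3 or the entering methoxy being meta to a methoxy group accounts for the gap.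

The compounds shown leave open how large the step truly is. They also leave open whether ethoxy or an amine in that place would give a similar step.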